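From 2-fluorophenyl to 1-methyl-1H-pyrazol-5-yl in the series

The source may report more compounds than this note shows. Statements on the series, on what has been measured and on what is new or still open speak of the compounds shown alone.

Measured in an ADME assay on L6 cells (Rattus norvegicus) for cytotoxicity, read by fluorescence and resazurin assay, with a stated time of 72 h; a lower number here means that less compound is needed, a higher number that more compound is needed for the effect:
- compound 1 `CN(C)c1ccc(-c2ccc3[nH]c(=O)nc(-c4ccccc4)c3c2)cn1`: 50000 nM
- compound 2 `O=c1nc(-c2ccccc2)c2cc(-c3ccccc3)ccc2[nH]1`: > 50000 nM (a limit of the assay)
- compound 3 `O=c1nc(-c2ccccc2)c2cc(-c3ccccc3F)ccc2[nH]1`: 55800 nM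

Compound 3, at 55800 nM, lies within the scatter of compound 1 at 50000 nM. Compound 4 `Cn1nccc1-c1ccc2[nH]c(=O)nc(-c3ccccc3)c2c1` carries 1-methyl-1H-pyrazol-5-yl in place of 2-fluorophenyl on an aromatic carbon. Among the measured compounds shown here, the only measured step, a step that the limit leaves unreadable from compound 2 to compound 3, gives no size to carry over. The expectation therefore rests on compound 1 at 50000 nM, whose aromatic group differs from that of compound 3 while the two values stay within the scatter. No change beyond the scatter is expected in this assay, and the expected size is a 1.1-fold lower number from compound 3 to compound 4 (0.05 log units; within the scatter). For compound 4 the estimate is 50000 nM, with an expected range of 25000 nM to 90000 nM.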

Compound 4, half-maximal effective concentration: > 50000 nM
Compound 4: a limit, no number; the forecaster's own chance of this, stated with the estimate: 45%; the middle value lies on the limit itself.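

Compound 4 gives > 50000 nM in this assay, which is a limit, so its steps from compound 2 and compound 3 cannot be read: the limit of > 50000 nM in this assay, at which 2 of the 4 values shown sit.

The compounds shown leave open whether 1-methyl-1H-pyrazol-5-yl, phenyl and 2-fluorophenyl differ at all in this assay.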